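The compounds below may be only part of what the source reports. "The series", "measured", "known", "first", "only" and "open" are said of these compounds alone.

Measured compounds: compound 1, `CC1=NN(C(=O)CN2CCCCC2)C(c2ccccc2O)C1`, gives 5890 nM; compound 2, `CNCC(=O)N1N=C(c2cc3ccccc3oc2=O)CC1c1ccccc1`, gives 2300 nM.

In a functional assay on PC-3 cells (Homo sapiens) for cytotoxicity, read by MTT assay, with a stated time of 48 h (on this read-out higher numbers stand for weaker inhibition and lower numbers for stronger inhibition), compound 2 holds the lower of the two numbers, and compound 1 stands at the higher one, with the gap between them lying beyond the usual scatter. Compound 3, `CN1CCN(CC(=O)N2N=C(c3cc4ccccc4oc3=O)CC2c2ccccc2)CC1`, is not yet measured. It differs from compound 2 in one place: 4-methylpiperazin-1-yl in place of methylamino on a saturated chain carbon bound to a carbonyl carbon. For the measured compounds named here, no measured pair shows this change, so no step can be drawn from the numbers. Compound 3 is expected to give a number close to that of compound 2, the step of a 1.2-fold higher number from compound 2 to compound 3 (0.09 log units; within the scatter) being estimated to lie within the scatter. The estimate for compound 3 is 2800 nM, in a range of 1200 nM to 7000 nM.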

Compound 3, half-maximal inhibitory concentration: 25800 nM
Estimate against measurement, compound 3: 9.2-fold (0.96 log units) below, outside the stated range (above it).
By their numbers in this assay, from the lowest: compound 2; then compound 1; then compound 3.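

In this assay, for the compounds shown here, the swap of methylamino for 4-methylpiperazin-1-yl on a saturated chain carbon bound to a carbonyl carbon gives an 11-fold higher number from compound 2 to compound 3 (1.05 log units; beyond the scatter) and so shows that this position does not treat these two amines alike, which the earlier compounds could not show. The change both adds a six-membered non-aromatic ring and removes the hydrogen-bond donor, and this single pair cannot separate the two. Nothing measured here bears on the reason for the step. The compounds shown leave open whether a morpholine or a dimethylamino group at this place would stay near compound 2 or fall near compound 3.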